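The source may report more compounds than this note shows. Statements on the series, on what has been measured and on what is new or still open speak of the compounds shown alone.

Measured so far:
Compound 1 `Cc1nc(S(C)(=O)=O)ccc1Oc1ncnc(OC2CCN(C(=O)O[C@H](C)CF)CC2)c1F` — in a functional assay on isolated protein for inhibition of Glucose-dependent insulinotropic receptor (Rattus norvegicus), read by HTRF and cAMP accumulation (on this read-out higher numbers stand for larger maximal responses and lower numbers for smaller maximal responses), compound 1 gives 79%.
Compound 2 `Cc1nc(S(C)(=O)=O)ccc1Oc1ncnc(OC2CCN(C(=O)O[C@@H](C)C(F)(F)F)CC2)c1F` — in this assay compound 2 gives 80%.

Compound 2 and compound 1 sit within the scatter of each other: the step of a number 1 percentage points higher from compound 1 to compound 2 (within the scatter) changes nothing that can be read as a difference. Compound 3 `Cc1nc(S(C)(=O)=O)ccc1Oc1ncnc(OC2CCN(C(=O)OC3COC3)CC2)c1F` has not yet been measured in this assay. Its difference from compound 2 is oxetan-3-yl in place of 1-(trifluoromethyl)ethyl on an oxygen next to a carbonyl group.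

For the measured compounds named here, only one measured step touches the same place, the oxygen next to the carbonyl group, and that step, a number 1 percentage points higher from compound 1 to compound 2 (within the scatter), was within the scatter. Going by the values given here, no measured step covers an oxetan-3-yl group. The data therefore give no footing for a step beyond the scatter in this assay, in either direction, and compound 3 is expected to land close to compound 2, with a step of a number 2 percentage points lower from compound 2 to compound 3 (within the scatter). Compound 3 is estimated at 78%, within a range from 65% to 90%.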

Compound 3, largest response reached (reported as efficacy), in percent of the reference or control that the assay uses: 66%
Compound 3: the middle estimate sits 12 percentage points above what was measured; the measured number falls inside the stated range.
By their numbers in this assay, from the lowest: compound 3; then compounds 1 and 2 (each within the scatter of the next).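

In this assay, the oxygen next to a carbonyl group proves sensitive to the group it carries: oxetan-3-yl in place of 1-(trifluoromethyl)ethyl gives a number 14 percentage points lower from compound 2 to compound 3 (beyond the scatter), and oxetan-3-yl in place of 1-(fluoromethyl)ethyl gives a number 13 percentage points lower from compound 1 to compound 3 (beyond the scatter). The only earlier step at this place stayed within the scatter, so oxetan-3-yl, with its four-membered ring and ring oxygen, is the first group shown here to move the maximal response beyond it. Nothing measured here accounts for the drop.

Since the ring, the ring oxygen and the loss of fluorine all come together in this change, the compounds shown cannot separate them. They also leave open how a cyclobutyl group, which has the four-membered ring without the oxygen, or a plain isopropyl group would read on this oxygen.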